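The source may report more compounds than this note shows. Statements on the series, on what has been measured and on what is new or still open speak of the compounds shown alone.

Measured so far in a functional assay on NCI-H23 cells (Homo sapiens) for cytotoxicity, read by sulforhodamine B assay, with a stated time of 48 h, tested at 100 uM; on this read-out higher numbers stand for a weaker effect at the one concentration tested and lower numbers for a stronger effect:
- compound 1 `COc1cc(-c2cc(/C=C/C(=O)c3ccc(Cl)c(Cl)c3)[nH]n2)cc(OC)c1OC`: 5%
- compound 2 `COc1ccc(-c2cc(/C=C/C(=O)c3ccc(N)cc3)[nH]n2)cc1OC`: -51%

Compound 1 stands highest of the two numbers in this assay, that is the weaker effect at the one concentration; compound 2 sits well below it, a gap beyond the scatter. Compound 3 `COc1cc(-c2cc(/C=C/C(=O)c3ccc(F)c(F)c3)[nH]n2)cc(OC)c1OC` is not yet measured in this assay. It differs from compound 1 by 3,4-difluorophenyl in place of 3,4-dichlorophenyl on a carbonyl carbon. Among the compounds with values here, no measured pair covers this change, so only a small step is expected here, none beyond the scatter, in either direction. Compound 3 is estimated at 10%, range -15% to 35%. That estimate means an expected step of a number 5 percentage points higher from compound 1 to compound 3 (within the scatter).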

Compound 3, a percentage reported as activity, at one concentration (the size of the read-out at that concentration, not a potency): -27%
Estimate against measurement, compound 3: 37 percentage points above, outside the stated range (below it).
By their numbers in this assay, from the lowest: compound 2; then compound 3; then compound 1.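

In this assay, 3,4-difluorophenyl in place of 3,4-dichlorophenyl on a carbonyl carbon gives a number 32 percentage points lower from compound 1 to compound 3 (beyond the scatter) and so a stronger effect at the one concentration tested. This position therefore responds to the choice of halogen, even though both groups have the same heavy-atom count and ring. Nothing at hand accounts for the step.

Going by these compounds, whether the read-out tracks the halogen remains open; an unsubstituted phenyl or a 3,4-dibromophenyl at this place could test that. Compound 2 differs from compound 1 and compound 3 in more than one place, so it cannot settle this.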